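Swapping a Sulfonate for Piperazine on the Shared Core

A few compounds are considered here, and "the series" means these few. Any claim that something is new, unique, unknown or untested is made for them only; others in the source may bear on it.

Measured so far:
compound 1, `CS(=O)(=O)Oc1c(C(=O)NCc2ccc(F)cc2)nc(Br)c2cccnc12`, this assay: > 20000 nM
compound 2, `COc1cccc(CNC(=O)c2nc(Br)c3cccnc3c2N[C@H]2CC[C@H](N)CC2)c1`, this assay: 6000 nM
compound 3, `N[C@H]1CC[C@H](NC(=O)c2nc(Br)c3cccnc3c2NCc2ccc(F)cc2)CC1`, this assay: 6400 nM

In a functional assay on HCT-116 cells (Homo sapiens) for cytotoxicity, read by MTT assay, with a stated time of 72 h (a higher number here means a weaker inhibitor, a lower number a stronger inhibitor), compound 1 gives > 20000 nM. That figure is a limit of the assay, not a measured number. Compound 1 thus stands at the weak end of the values shown, where (the limit of > 20000 nM in this assay, at which 1 of the 3 values shown sits). Compound 2 gives 6000 nM and compound 3 gives 6400 nM; these two values lie within the usual scatter of each other.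

Compound 4 `O=C(NCc1ccc(F)cc1)c1nc(Br)c2cccnc2c1N1CCNCC1` has not yet been measured. It differs from compound 1 in one place: piperazin-1-yl in place of (methylsulfonyl)oxy on an aromatic carbon. Among the compounds with values here, no step between two measured compounds is available to calibrate this change, so the expectation rests on the three values alone. Because compound 1 shows only > 20000 nM, a limit, any measurable result for compound 4 would count as a gain; the step from compound 1 to compound 4 is expected to be a modest improvement, as an at least 2.5-fold lower number from compound 1 to compound 4 (0.39 log units; beyond the scatter). Compound 4 is estimated to give 8000 nM, with a range from 2500 nM to 30000 nM.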

Compound 4, half-maximal inhibitory concentration: > 10000 nM
Compound 4: no number, only a limit; the forecaster's own chance of this, stated with the estimate: 30%; middle value at least 1.2-fold (0.09 log units) away from the limit.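

Compound 4 gives > 10000 nM, which is a limit and not a number. Compound 1 also shows only a limit, and the step between compound 1 and compound 4 cannot be read. On these data alone, whether piperazin-1-yl in place of (methylsulfonyl)oxy strengthens or weakens cytotoxicity remains open.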